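Replacing the indanyl amide substituent with a piperidinyl group

The source may hold more compounds than are shown below. What is called first, only, known or untested is meant among the compounds shown, and "the series" means these compounds.

Measured compounds:
compound 1 `Cc1ccc(S(=O)(=O)N2C=CNC(=O)[C@H]2CC(=O)N[C@@H]2CCCc3cc(CN4CCCC4)ccc32)cc1` 0.084 nM
compound 2 `Cc1ccc(S(=O)(=O)N2C=CNC(=O)[C@H]2CC(=O)N[C@@H]2CCc3ccccc32)cc1` 94.7 nM

In an in vitro functional assay on cells for antagonist activity at B1 bradykinin receptor (Homo sapiens), read by luminescence and calcium flux, with a stated time of 2 h (on this read-out higher numbers stand for weaker inhibition and lower numbers for stronger inhibition), compound 2 gives 94.7 nM, the highest of the two numbers measured. Its nearest neighbour is compound 1, which in this assay gives 0.084 nM; the gap between these two values is far beyond the scatter of repeated measurements.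

Compound 3 `Cc1ccc(S(=O)(=O)N2C=CNC(=O)[C@H]2CC(=O)N[C@H]2CCN(C)CC2(C)C)cc1` has not yet been measured. It differs from compound 2 in one place: a group of 9 heavy atoms (8 carbon, 1 nitrogen; one six-membered non-aromatic ring with 1 hetero atom) in place of a group of 9 heavy atoms (9 carbon; one five-membered non-aromatic ring of carbon only, one six-membered aromatic ring of carbon only), on an amide-type nitrogen. The group that enters carries one hydrogen-bond acceptor and contains a nitrogen, while the indanyl group it replaces has none.

Only the two measured values give any footing here, and neither differs from compound 2 in this single place, so the direction of the step is uncertain. The group that enters shares the presence of a nitrogen with the substituent of compound 1, which gives 0.084 nM, and on that thin basis a moderate lowering of the number in this assay is expected, amounting to a 3.2-fold lower number from compound 2 to compound 3 (0.50 log units; beyond the scatter). Compound 3 is therefore estimated at 30 nM, within a range of 3 nM to 300 nM.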

Compound 3, half-maximal inhibitory concentration: 0.42 nM
Compound 3: middle estimate off by 71-fold (1.85 log units), on the high side; measured number outside the range, below it.
By their numbers in this assay, from the lowest: compound 1; then compound 3; then compound 2.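

In this assay the substituent on the amide-type nitrogen turns out to be a strong lever on the number, with a 230-fold lower number from compound 2 to compound 3 (2.35 log units; beyond the scatter) for a single change in that place. The 2,3-dihydro-1H-inden-1-yl group can therefore give way to a six-membered non-aromatic ring with one hetero atom, of equal heavy-atom count and without any aromatic ring in the group, and inhibition grows stronger rather than being lost. Nothing measured here accounts for the size of this step.

The compounds shown leave open whether the ring nitrogen itself carries the step, which a cyclohexyl group of carbon only in the same place would test. They also leave open what the methyl groups on the entering ring contribute, which a plain piperidin-4-yl group would address.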